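The source may hold more compounds than are shown below. What is called first, only, known or untested is meant among the compounds shown, and "the series" means these compounds.

Within the data shown here, compound 1 `OCC#CCSc1cnc2ccccc2c1[Se]CC#CCO` gives the lowest of the two numbers so far in a functional assay on P388 cells (Mus musculus) for cytotoxicity, read by MTT assay, with a stated time of 72 h (on this read-out lower numbers stand for stronger inhibition and higher numbers for weaker inhibition), at 4.1 ug/mL. Compound 2 `COc1c(SCC#CCO)cnc2ccccc12` gives 23.2 ug/mL in this assay; the step of a 5.7-fold higher number from compound 1 to compound 2 (0.75 log units; beyond the scatter) removes the chain that carries the hydroxymethyl entirely, so it bears only loosely on the change to compound 3 `C#CC[Se]c1c(SCC#CCO)cnc2ccccc12`. That change is hydrogen in place of hydroxymethyl on a triple-bonded carbon. Among the measured compounds shown here, no measured step alters the group on a triple-bonded carbon alone; a step smaller than a 5.7-fold higher number from compound 1 to compound 2 (0.75 log units; beyond the scatter), if beyond the scatter at all, is expected, towards a higher number. Compound 3 is therefore expected at 6 ug/mL, between 2.5 ug/mL and 15 ug/mL, a step of a 1.5-fold higher number from compound 1 to compound 3 (0.17 log units; within the scatter).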

Compound 3, concentration for 50% inhibition: 2.5 ug/mL
The estimate for compound 3 lay 2.4-fold (0.38 log units) above the measured number, and the stated range covers the measured number.
By their numbers in this assay, from the lowest: compounds 3 and 1 (each within the scatter of the next); then compound 2.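

In this assay, hydrogen in place of hydroxymethyl on a triple-bonded carbon gives a 1.6-fold lower number from compound 1 to compound 3 (0.21 log units; within the scatter), so compound 1 and compound 3 cannot be told apart and this terminal hydroxymethyl is dispensable here. The propargyl compound also keeps the gap to the compound with the smaller group, with a 9.3-fold lower number from compound 2 to compound 3 (0.97 log units; beyond the scatter). No evidence on the cause of either step is available. From the compounds shown here alone, whether an amine or a longer chain on that triple-bonded carbon would fit the same picture remains open, as does the same change on the remaining 4-hydroxybut-2-yn-1-yl chain.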